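A few compounds are considered here, and "the series" means these few. Any claim that something is new, unique, unknown or untested is made for them only; others in the source may bear on it.

Of the compounds shown here, three share one core and have been tested in a functional assay on CHO cells for agonist activity at adenosine receptor A1 (Homo sapiens), read by ERK phosphorylation, tested at 10 uM; a higher number here means a stronger effect of the compound at the concentration tested, a lower number a weaker effect. Compound 1 `NNC(=O)c1c(N)sc2c1CCCCCC2` gives 48%, compound 2 `Nc1sc2c(c1C(=O)NNc1ccccc1)CCCCCC2` gives 43%, and compound 3 `Nc1sc2c(c1C(=O)NCc1ccccc1)CCCCCC2` gives 50%. The figure of compound 3 is nominally the highest of the three, but the step of a number 2 percentage points higher from compound 1 to compound 3 (within the scatter) and the step of a number 7 percentage points higher from compound 2 to compound 3 (within the scatter) both lie within the scatter, as does the step of a number 5 percentage points lower from compound 1 to compound 2 (within the scatter), so the three compounds cannot be told apart on these numbers.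

Compound 4 `Nc1sc2c(c1C(=O)NCc1cccc(Cl)c1)CCCCCC2` differs from compound 3 by chloro in place of hydrogen on an aromatic carbon. Going by the values given here, none of the measured steps touches the aromatic ring itself: all three alter the group on the amide-type nitrogen, and all three are within the scatter. Among the compounds with values here, with no step of a comparable kind available, the only guidance is that every change made so far has left this assay essentially unmoved.

Compound 4 is therefore expected to give about 50% in this assay, within a range from 35% to 65%. The step this implies, no change at the digits printed from compound 3 to compound 4 (within the scatter), is estimated to stay within the scatter.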

Compound 4, a percentage reported as activity, at one concentration (the size of the read-out at that concentration, not a potency): 47%
For compound 4 the middle estimate is 3 percentage points above the measured one; the measured number falls inside the stated range.
By their numbers in this assay, from the lowest: compounds 2, 4, 1 and 3 (each within the scatter of the next).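

Chloro on the aromatic ring is the first change shown that reaches the ring of the benzyl group, rather than replacing the whole group on the amide-type nitrogen. In this assay it gives a number 3 percentage points lower from compound 3 to compound 4 (within the scatter), so at this place, on an aromatic carbon meta to a large group, the step from phenyl to 3-chlorophenyl does not separate the two compounds, and the ring joins the amide-type nitrogen as a site where no difference can be read. No measurement available here bears on this result.

The compounds shown leave open whether a carboxylic acid or an amine at this same place, or chloro on another carbon of the ring, would stand apart from compound 3. All the numbers come from a single concentration, so they tell only the size of the effect at that concentration, and whether any of these compounds would give a stronger or weaker effect at another concentration remains open.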